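This account rests on a few compounds, and the source may have more. Where it says the series, first, only, none or still open, it means among the compounds named here.

In an ADME assay on the whole organism (strain Sprague-Dawley) for pharmacokinetics, with Rattus norvegicus as the target, using cassette dosing (a lower number here means slower removal, a higher number faster removal of the compound), compound 1 (`O=C(C[C@]1(O)CC[C@@H](Cc2ccccc2)CC1)Nc1ccc2[nH]c(=O)oc2c1`) gives 34.1 mL/min/kg and compound 2 (`O=C(C[C@]1(O)CC[C@H](Cc2ccccc2)CC1)Nc1ccc2[nH]c(=O)oc2c1`) gives 35.1 mL/min/kg so the two stand level. They differ only in their drawn configuration (the fact that compounds 1 and 2 differ only in the configuration as drawn), and that step (a 1.0-fold higher number from compound 1 to compound 2 (0.01 log units; within the scatter)) is the only one measured. Compound 3 (`O=C(C[C@]1(O)CC[C@@H](Cc2ccc(F)cc2)CC1)Nc1ccc2[nH]c(=O)oc2c1`) brings a different kind of change to compound 1 (fluoro in place of hydrogen on an aromatic carbon), as benzyl becomes 4-fluorobenzyl. Going by the values given here, no measured step covers this change, so no shift beyond the scatter, in either direction, is expected (a 1.1-fold lower number from compound 1 to compound 3 (0.03 log units; within the scatter)). The clearance of compound 3 is estimated at 32 mL/min/kg with an expected range of 16 mL/min/kg to 60 mL/min/kg for now.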

Compound 3, clearance: 36.8 mL/min/kg
Compound 3: the middle estimate sits 1.2-fold (0.06 log units) below what was measured; the measured number falls inside the stated range.
By their numbers in this assay, from the lowest: compounds 1, 2 and 3 (each within the scatter of the next).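

Fluoro in place of hydrogen on the aromatic carbon para to a large group, with benzyl becoming 4-fluorobenzyl, gives a 1.1-fold higher number from compound 1 to compound 3 (0.03 log units; within the scatter) in this assay. Going by these compounds alone, this is the first look at a change on this ring rather than in drawn configuration, and this position takes a single fluoro with clearance still level with compound 1. Nothing available explains why the clearance stands level here.

Still open, from the compounds shown here alone, is what a methoxy, an amine or a carboxylic acid would do at this position. Also open, going by these compounds, is whether fluoro elsewhere on the ring, or on the mirror-image compound 2, would read the same.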